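Dropping the Methyl on an Aromatic Nitrogen

This account rests on a few compounds, and the source may have more. Where it says the series, first, only, none or still open, it means among the compounds named here.

Measured compounds:
compound 1 `O=C1NCCC12CCN(c1c(-c3ccc4ncsc4c3)cnc3[nH]ccc13)CC2` with 80 nM
compound 2 `Cn1cnc2cc(-c3cnc4[nH]ccc4c3N3CCC4(CCNC4=O)CC3)ccc21` with 50 nM

Of the compounds shown here, two have been measured in an assay on cells for binding affinity to Cyclin-C/Cyclin-dependent kinase 19 (Homo sapiens), read by LanthaScreen; a lower number here means a stronger inhibitor, a higher number a weaker inhibitor. Compound 1 gives 80 nM and compound 2 gives 50 nM. Within the data shown here, compound 2 has the lowest of the two numbers, but its only neighbour is compound 1, and the gap between them, a 1.6-fold lower number from compound 1 to compound 2 (0.20 log units; within the scatter), lies within the scatter, so the two cannot be ordered.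

Compound 3 `O=C1NCCC12CCN(c1c(-c3ccc4[nH]cnc4c3)cnc3[nH]ccc13)CC2` is the next compound. It differs from compound 2 in one place: hydrogen in place of methyl on an aromatic nitrogen. Among the measured compounds shown here, the only measured step, a 1.6-fold lower number from compound 1 to compound 2 (0.20 log units; within the scatter), swapped one fused ring system for another and says nothing direct about the methyl on the ring nitrogen. For the measured compounds named here, no measured pair shows what removing that methyl does. Going by the values given here, with no step bearing on the change, the expectation rests on the shared core and the neighbouring ring system staying in place, and the expected outcome in this assay is no shift beyond the scatter. The expected step is a 1.2-fold higher number from compound 2 to compound 3 (0.08 log units; within the scatter). Compound 3 is estimated at 60 nM, with a range from 25 nM to 150 nM.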

Compound 3, half-maximal inhibitory concentration: 17 nM
Compound 3: middle estimate off by 3.5-fold (0.55 log units), on the high side; measured number outside the range, below it.
By their numbers in this assay, from the lowest: compound 3; then compounds 2 and 1 (each within the scatter of the next).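

Taking the methyl off the aromatic nitrogen proves to be a real change in this assay: the 1-methyl-1H-benzimidazol-5-yl to 1H-benzimidazol-5-yl swap gives a 2.9-fold lower number from compound 2 to compound 3 (0.47 log units; beyond the scatter) and so moves the number beyond the scatter, which the one earlier step did not do. Among these compounds, the fused ring systems can now be told apart as well, since 1H-benzimidazol-5-yl in place of 1,3-benzothiazol-6-yl gives a 4.7-fold lower number from compound 1 to compound 3 (0.67 log units; beyond the scatter) and makes compound 3 the only compound whose steps to both others lie beyond the scatter. No measurement here explains why the ring nitrogen with hydrogen gives the lowest number.

This single pair cannot show whether any group on that nitrogen raises the number or only methyl does, and an ethyl or a longer chain in the same place would test that. From the compounds shown here alone, whether the same step appears with another group in place of the spiro lactam part of the shared core, such as an amine, also remains open.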